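Swapping an amide for a sulfonamide on a shared core

A few compounds are considered here, and "the series" means these few. Any claim that something is new, unique, unknown or untested is made for them only; others in the source may bear on it.

Of the compounds shown here, two built on the same core have been measured in an ADME assay on MDCK cells (Canis lupus familiaris) for permeability; a higher number here means that the compound crosses the layer faster, a lower number that the compound crosses the layer more slowly. Compound 1 `CCS(=O)(=O)Nc1ccc(Oc2ccccc2)c(-c2cn(C)c(=O)c3[nH]ccc23)c1` gives 22 10^-6 cm/s. Compound 2 `Cn1cc(-c2cc(C(N)=O)ccc2Oc2ccccc2)c2cc[nH]c2c1=O` gives 14 10^-6 cm/s, which is the lowest of the two numbers, though the step of a 1.6-fold lower number from compound 1 to compound 2 (0.20 log units; within the scatter) lies within the scatter, so the two cannot be told apart.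

Compound 3 `Cn1cc(-c2cc(S(N)(=O)=O)ccc2Oc2ccccc2)c2cc[nH]c2c1=O` carries the change (sulfamoyl in place of carbamoyl on an aromatic carbon). Going by the values given here, the only measured step, a 1.6-fold lower number from compound 1 to compound 2 (0.20 log units; within the scatter), concerns a different exchange at the same place and does not involve a sulfamoyl group, so it bears on the new step only in showing that replacing one group at this carbon left this assay largely unchanged. Among the compounds with values here, no measured pair speaks directly to a sulfamoyl group. The expectation for compound 3 is therefore a small downward step, a 1.6-fold lower number from compound 2 to compound 3 (0.19 log units; within the scatter), that may well stay within the scatter. Compound 3 is estimated at 9 10^-6 cm/s in this assay, with a range from 4 10^-6 cm/s to 18 10^-6 cm/s.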

Compound 3, apparent permeability: 22 10^-6 cm/s
Compound 3: middle estimate off by 2.4-fold (0.39 log units), on the low side, outside the stated range (above it).
By their numbers in this assay, from the lowest: compounds 2, 1 and 3 (each within the scatter of the next).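

In this assay, sulfamoyl now joins carbamoyl and (ethylsulfonyl)amino as a third group read on this aromatic carbon, para to a phenoxy group, and the exchange of carbamoyl for sulfamoyl gives a 1.6-fold higher number from compound 2 to compound 3 (0.20 log units; within the scatter), so these two compounds cannot be told apart. Replacing (ethylsulfonyl)amino with sulfamoyl gives no change at the digits printed from compound 1 to compound 3 (within the scatter), which means that all three groups on the shared core now sit within the scatter of one another, even though carbamoyl and sulfamoyl differ in their heavy atoms and in their counts of hydrogen-bond acceptors. No separate measurement accompanies these compounds that could account for this result.

Carbamoyl and sulfamoyl both carry no net charge, so it remains open whether an amine or a carboxylic acid on this same aromatic carbon would stay within the scatter of these three compounds in this assay. A longer chain on the sulfonyl group, or the same exchanges with something other than the phenoxy group in place, also remains an open case.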